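Removing one chloro from the dichlorophenyl sulfonamide

A few compounds are considered here, and "the series" means these few. Any claim that something is new, unique, unknown or untested is made for them only; others in the source may bear on it.

Compound 1 `O=S(=O)(Nc1ccc2oc(-c3ccccc3)nc2c1)c1ccc(Cl)c(Cl)c1` is tested in an assay on isolated protein for inhibition of malate dehydrogenase, mitochondrial (Sus scrofa), with stated times of 45 min and 30 min; on this read-out higher numbers stand for weaker inhibition and lower numbers for stronger inhibition. In this assay compound 1 returns only a limit, > 63000 nM. Compound 2 `O=S(=O)(Nc1ccc(-c2nc3ccccc3o2)cc1)c1ccccc1F` likewise returns a limit in this assay, > 63000 nM. Compound 1 thus stands at the limit of > 63000 nM in this assay, at which 2 of the 2 values shown sit, with no number to place it. Compound 3 `O=S(=O)(Nc1ccc2oc(-c3ccccc3)nc2c1)c1ccc(Cl)cc1` differs from compound 1 by hydrogen in place of chloro on an aromatic carbon. Within the data shown here, no step between measured compounds is available, and compound 1 shows nothing measurable. Compound 3 is therefore expected to give no step beyond the scatter, a step that the limit leaves unreadable from compound 1 to compound 3, most likely again a limit. The estimate for compound 3 is 80000 nM, with a range of 30000 nM to 250000 nM.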

Compound 3, half-maximal inhibitory concentration: > 63000 nM
Compound 3: a limit, no number; the forecaster's own chance of this, stated with the estimate: 85%; the middle value does not contradict the limit.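

In this assay compound 1 and compound 3 both return only limits, so no step between them can be read: the limit of > 63000 nM in this assay, at which 3 of the 3 values shown sit.

The compounds shown leave open whether the 3,4-dichlorophenyl to 4-chlorophenyl change has any effect on inhibition, and whether any compound of this series reaches a measurable value in this assay.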